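This account rests on a few compounds, and the source may have more. Where it says the series, first, only, none or still open, it means among the compounds named here.

Measured so far in an assay on HEK293 cells for agonist activity at transient receptor potential cation channel subfamily M member 8 (Homo sapiens), read by fluorescence and calcium flux, with a stated time of 15 min; on this read-out higher numbers stand for an effect only at larger amounts of compound and lower numbers for an effect already at smaller amounts:
Compound 1 `CCN(Cc1ccc(C)s1)C(=O)COc1ccc(C)cc1`: 178 nM
Compound 2 `CCN(Cc1cccs1)C(=O)COc1ccc(C(C)C)cc1`: 397 nM
Compound 3 `Cc1ccc(OCC(=O)N(Cc2cccs2)CC(C)C)cc1`: 900 nM

Compound 3 stands at the highest of the three numbers in this assay. Its nearest neighbour is compound 2, whose number is lower by an amount beyond the usual scatter; compound 1 lies further off, lower again and also beyond the scatter. For the measured compounds named here, the three measured compounds differ from one another in more than one place, so no single-change step is available, and the move to compound 4 `Cc1ccc(OCC(=O)N(Cc2cccs2)c2ccn(C)n2)cc1` rests on the structural change alone: 1-methyl-1H-pyrazol-3-yl in place of isobutyl on an amide-type nitrogen.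

Going by the values given here, no measured pair shows what this particular exchange does in this assay. Compound 3 is the weakest of the three and is built differently from compounds 1 and 2 at several places at once, so nothing clean about the amide-type nitrogen follows from them. The step from compound 3 to compound 4 is expected to be small to moderate, with the direction uncertain and a rise taken as the working assumption, a 1.7-fold higher number from compound 3 to compound 4 (0.22 log units; within the scatter). For compound 4 the estimate in this assay is 1500 nM, with a range from 400 nM to 6000 nM.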

Compound 4, half-maximal effective concentration: 855 nM
Compound 4: middle estimate off by 1.8-fold (0.24 log units), on the high side; low and high end bracket the measured number.
By their numbers in this assay, from the lowest: compound 1; then compound 2; then compounds 4 and 3 (each within the scatter of the next).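

In this assay, for the compounds shown here, 1-methyl-1H-pyrazol-3-yl in place of isobutyl on the amide-type nitrogen gives a 1.1-fold lower number from compound 3 to compound 4 (0.02 log units; within the scatter), the only single-change step available, and it lies within the scatter. In this one pair, a group of 4 heavy atoms with no ring gives way to one of 6 heavy atoms with one five-membered aromatic ring and 2 hydrogen-bond acceptors, and the read-out does not separate the two compounds. No measurement at hand bears on why the two groups read alike.

From the compounds shown here alone, compound 1 and compound 2 differ from compound 3 and compound 4 in more than one place, so it stays open whether the same exchange would read the same way on their substitution pattern, and one pair establishes no trend for this position. Also open, going by these compounds, is what a chain carrying a dimethylamino group, a carboxylic acid, a phenyl ring or a longer chain such as n-hexyl would do on this nitrogen, and whether any group there can move the number beyond the scatter in either direction.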